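Swapping a Cyanobenzimidazole for a Benzothiazole

This account rests on a few compounds, and the source may have more. Where it says the series, first, only, none or still open, it means among the compounds named here.

Compound 1 `N#Cc1ccc2[nH]c(-c3cccc(NC(=S)NC(=O)c4ccc5c(c4)OCCO5)c3)nc2c1` was tested in a functional assay on HUVEC cells (Homo sapiens) for cytotoxicity, read by WST assay, with a stated time of 48 h (a higher number here means a weaker inhibitor, a lower number a stronger inhibitor), where compound 1 gives 1000 nM. Among the three compounds measured so far, this is the second highest number. Compound 3 `Cc1ccc(-c2nc3ccccc3[nH]2)cc1NC(=S)NC(=O)c1ccc2c(c1)OCCO2` gives 240 nM, a lower number beyond the usual scatter, while compound 2 `COc1ccc(C(=O)NC(=O)Nc2cccc(-c3nc4ccccc4[nH]3)c2)cc1OC` gives 8000 nM, a higher number beyond the scatter. Compound 4 `O=C(NC(=S)Nc1cccc(-c2nc3ccccc3s2)c1)c1ccc2c(c1)OCCO2` is not yet measured. It differs from compound 1 in a single place: 1,3-benzothiazol-2-yl in place of 5-cyano-1H-benzimidazol-2-yl on an aromatic carbon. Within the data shown here, no measured pair shows this particular exchange, so its effect cannot be read from the numbers in hand. A modest step is expected, leaning toward a weaker inhibitor, a 1.5-fold higher number from compound 1 to compound 4 (0.18 log units; within the scatter), though a result within the scatter would not surprise. In this assay compound 4 is estimated at 1500 nM, with a range from 300 nM to 8000 nM.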

Compound 4, half-maximal inhibitory concentration: 2600 nM
For compound 4 the middle estimate is 1.7-fold (0.24 log units) below the measured one; the measured number falls inside the stated range.
By their numbers in this assay, from the lowest: compound 3; then compound 1; then compound 4; then compound 2.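

In this assay, the group on this aromatic carbon makes a difference: 1,3-benzothiazol-2-yl in place of 5-cyano-1H-benzimidazol-2-yl gives a 2.6-fold higher number from compound 1 to compound 4 (0.41 log units; beyond the scatter) and so a weaker inhibitor. The exchange alters several features at once, removing the nitrile and the hydrogen-bond donor and adding sulfur, so this one step cannot show which of them counts. No measurement here accounts for the shift.

Still open, as far as these compounds go, is how a 1H-benzimidazol-2-yl without the nitrile, or one carrying an amine in its place, would compare on this carbon.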